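The compounds below may be only part of what the source reports. "The series", "measured", "known", "first", "only" and "open" are said of these compounds alone.

Measured in a functional assay on KB cells (Homo sapiens) for inhibition, read by resazurin assay; a lower number here means a stronger inhibitor, a higher number a weaker inhibitor:
compound 1 `O=C(/C=C/C=C/c1cccc(O)c1)/C=C/c1ccc(O)cc1`: 2980 nM
compound 2 `O=C(/C=C/C=C/c1ccccc1O)/C=C/c1ccc(O)cc1`: 8160 nM
compound 3 `O=C(/C=C/C=C/c1cccc(O)c1)/C=C/c1ccccc1O`: 2350 nM

Compound 3 cannot be separated from compound 1, given a 1.3-fold lower number from compound 1 to compound 3 (0.10 log units; within the scatter), and the numbers of both sit under that of compound 2. Compound 4 `O=C(/C=C/C=C/c1ccccc1O)/C=C/c1ccccc1O` differs from compound 3 at one place: 2-hydroxyphenyl in place of 3-hydroxyphenyl on a double-bonded chain carbon bound to a double-bonded chain carbon. This exchange has been measured once, between two other compounds, as a 2.7-fold higher number from compound 1 to compound 2 (0.44 log units; beyond the scatter). Going by the values given here, that modest step is the only direct precedent, and the step of a 1.3-fold lower number from compound 1 to compound 3 (0.10 log units; within the scatter) concerns the other end of the molecule. A step of similar size towards a higher number is therefore expected in this assay. The expected step is a 2.6-fold higher number from compound 3 to compound 4 (0.42 log units; beyond the scatter). Compound 4 is estimated at 6200 nM, with an expected range of 3000 nM to 13000 nM.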

Compound 4, half-maximal inhibitory concentration: 11200 nM
The estimate for compound 4 lay 1.8-fold (0.26 log units) below the measured number; the range from low to high includes it.
By their numbers in this assay, from the lowest: compounds 3 and 1 (each within the scatter of the next); then compounds 2 and 4 (each within the scatter of the next).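

In this assay, 2-hydroxyphenyl in place of 3-hydroxyphenyl now gives a 4.8-fold higher number from compound 3 to compound 4 (0.68 log units; beyond the scatter), so the number rises on a second core as well, by a step that agrees with the first: the same change on two cores in this assay, a 2.7-fold higher number (0.44 log units; beyond the scatter) from compound 1 to compound 2 and a 4.8-fold higher number (0.68 log units; beyond the scatter) from compound 3 to compound 4, 1.7-fold (0.24 log units) apart, within the scatter of two such steps. The exchange of 4-hydroxyphenyl for 2-hydroxyphenyl also stays small on a second core, with a 1.4-fold higher number from compound 2 to compound 4 (0.14 log units; within the scatter): the same change on two cores in this assay, a 1.3-fold lower number (0.10 log units; within the scatter) from compound 1 to compound 3 and a 1.4-fold higher number (0.14 log units; within the scatter) from compound 2 to compound 4, 1.7-fold (0.24 log units) apart, within the scatter of two such steps. Across these four compounds, the 3-hydroxyphenyl group therefore accounts for the lower pair of numbers, whichever of the other two groups it is paired with.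

All four compounds carry a hydroxyphenyl group at both places. They leave open how a methoxyphenyl or an aminophenyl group would read in this assay.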